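Propanoyl on the sulfonamide nitrogen in a paw edema series

This account rests on a few compounds, and the source may have more. Where it says the series, first, only, none or still open, it means among the compounds named here.

Measured compounds:
compound 1, `CCC(=O)OCc1cc(-n2nc(C(F)F)cc2-c2ccc(Br)cc2)ccc1S(N)(=O)=O`: 40 mg/kg
compound 2, `CCC(=O)NS(=O)(=O)c1ccc(-n2nc(C(F)F)cc2-c2ccc(Br)cc2)cc1COC(=O)CC`: 45 mg/kg
compound 3, `CCC(=O)OCc1cc(-n2nc(C(F)(F)F)cc2-c2ccc3c(c2)CCC3)ccc1S(N)(=O)=O`: 30 mg/kg

All three were read in a functional assay on the whole organism (strain Wistar) with Rattus norvegicus as the target, read by paw edema, at a dose of 30 mg/kg by the oral route; a higher number here means that more compound is needed for the effect, a lower number that less compound is needed. Compound 2 differs from compound 1 by propanoyl in place of hydrogen on a sulfonamide nitrogen, and the step is a 1.1-fold higher number from compound 1 to compound 2 (0.05 log units; within the scatter). Compound 3 and compound 1 carry different cores; that difference is not broken down here. The value of compound 3 lies within the scatter of the values of compound 1 and compound 2, so no order among the three is claimed.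

Compound 4, `CCC(=O)NS(=O)(=O)c1ccc(-n2nc(C(F)(F)F)cc2-c2ccc3c(c2)CCC3)cc1COC(=O)CC`, is not yet measured. It differs from compound 3 by propanoyl in place of hydrogen on a sulfonamide nitrogen, the same change as between compound 1 and compound 2, made in the same place. Among the measured compounds shown here, for compound 4 the expected step is a 1.1-fold higher number from compound 3 to compound 4 (0.04 log units; within the scatter), resting only on the single earlier step of a 1.1-fold higher number from compound 1 to compound 2 (0.05 log units; within the scatter). Compound 4 is therefore expected to give about 33 mg/kg in this assay, between 18 mg/kg and 60 mg/kg.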

Compound 4, dose for half-maximal effect: 41 mg/kg
Compound 4: the middle estimate sits 1.2-fold (0.09 log units) below what was measured; the measured number falls inside the stated range.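

In this assay, propanoyl in place of hydrogen on the sulfonamide nitrogen gives a 1.4-fold higher number from compound 3 to compound 4 (0.14 log units; within the scatter). Set beside the earlier step, the change reads alike on both cores: the same change on two cores in this assay, a 1.1-fold higher number (0.05 log units; within the scatter) from compound 1 to compound 2 and a 1.4-fold higher number (0.14 log units; within the scatter) from compound 3 to compound 4, 1.2-fold (0.08 log units) apart, within the scatter of two such steps. Among the compounds shown here, this shows that, across these two cores, the change gives no step that can be told from the scatter; it does not show that the same would hold on other cores, and two pairs set no rule for the series.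

Still open, going by these compounds, is whether a different group on the sulfonamide nitrogen, such as acetyl, benzoyl or a longer acyl chain, would give a step beyond the scatter. Also open, on these data alone, is how that nitrogen would read with a simple alkyl group in place of the acyl.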